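Acrylamide warhead in place of bromopropanamide on compound 1

The compounds below may be only part of what the source reports. "The series", "measured", "known", "first", "only" and "open" are said of these compounds alone.

Compound 1 `COc1ccc(CN(C(=O)C(C)Br)c2cc(OC)c(OC)c(OC)c2)cc1O` is the stronger of the two compounds measured in a functional assay on HCT-116 cells (Homo sapiens) for inhibition, read by MTT assay, with a stated time of 48 h (a higher number here means a weaker inhibitor, a lower number a stronger inhibitor), where compound 1 gives 140 nM. Going by the values given here, the only comparator is compound 2 `COc1cc(NCc2cccc(O)c2)cc(OC)c1OC`, a secondary aniline lacking the amide carbonyl altogether; in this assay compound 2 gives 67700 nM, a gap far beyond the scatter, though no single-point step connects the two structures.

Compound 3 `C=CC(=O)N(Cc1ccc(OC)c(O)c1)c1cc(OC)c(OC)c(OC)c1` has not been measured. It keeps the core of compound 1 and changes only the acyl group: vinyl in place of 1-bromoethyl on a carbonyl carbon. Among the compounds with values here, no measured step of this kind exists, so the size of the effect in this assay is unknown; the expectation is a step of no more than modest size in either direction, most likely within the scatter, since the core that separates compound 1 from compound 2 is retained.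

On that basis compound 3 is expected to give 200 nM in this assay, with a plausible range of 40 nM to 1000 nM, the step expected being a 1.4-fold higher number from compound 1 to compound 3 (0.15 log units; within the scatter).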

Compound 3, half-maximal inhibitory concentration: 98 nM
Beside the measured number, compound 3's estimate is 2.0-fold (0.31 log units) above it, within the range that was stated.
By their numbers in this assay, from the lowest: compounds 3 and 1 (each within the scatter of the next); then compound 2.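

In this assay, the acyl group on the amide-type nitrogen now has its first single-place reading: vinyl in place of 1-bromoethyl on a carbonyl carbon gives a 1.4-fold lower number from compound 1 to compound 3 (0.15 log units; within the scatter). The bromine and the saturated two-carbon fragment of 1-bromoethyl are therefore not required to hold the activity of this core, and a vinyl group on the same carbonyl carbon serves equally well within the scatter, something the comparison of compound 1 with compound 2, which differ in more than one place, could not show. Nothing available on the series bears on why the two acyl groups read alike.

From the compounds shown here alone, whether the position needs either a bromine or a double bond remains open: a plain ethyl on the same carbonyl carbon would separate these cases, while a longer chain or a dimethylamino-bearing chain there would test how much change the position accepts. The compounds shown also give no single-place reading on the hydroxyl and methoxy groups of the shared core, so the contribution of each to the activity in this cell assay is unresolved.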